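The compounds below may be only part of what the source reports. "The series", "measured", "known", "first", "only" and "open" are said of these compounds alone.

In an ADME assay on J774 cells (Mus musculus) for cytotoxicity, with a stated time of 72 h (on this read-out higher numbers stand for an effect only at larger amounts of compound and lower numbers for an effect already at smaller amounts), compound 3 `COC(=O)c1c[nH]c2cc(N3CCN(c4ccccc4)CC3)c(OC)cc2c1=O` gives 17000 nM. Compound 2 `COC(=O)c1c[nH]c2cc(N3CCN(c4ccccc4)CC3)c(C)cc2c1=O` stands level with it at 17000 nM. Compound 1 `COC(=O)c1c[nH]c2cc(CN3CCN(c4ccc(C(F)(F)F)cc4)CC3)c(OC)cc2c1=O` gives > 20000 nM, which is a limit of the assay and not a number. So compound 3 sits among values that need large amounts of compound before any effect on the cells appears.

The next compound, compound 4 `COC(=O)c1c[nH]c2cc(N3CCN(c4ccc(OC)cc4)CC3)c(OC)cc2c1=O`, differs from compound 3 by a single change, methoxy in place of hydrogen on an aromatic carbon, para to a large group. For the measured compounds named here, the only measured step that bears on this is no change at the digits printed from compound 2 to compound 3 (within the scatter). That step also brings in a methoxy, but it replaces methyl at a different place, so it is only a loose guide. Going by the values given here, no measured step adds a group at this carbon.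

On that slim evidence, no step beyond the scatter is expected, and the expected change is no change at the digits printed from compound 3 to compound 4 (within the scatter). Compound 4 could also return just a limit, namely (the limit of > 20000 nM in this assay, at which 1 of the 3 values shown sits). For compound 4 the estimated value is 17000 nM, with an expected range from 9000 nM to 30000 nM.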

Compound 4, half-maximal effective concentration: > 20000 nM
Compound 4: only a limit was reported; the forecaster's own chance of this, stated with the estimate: 35%; at least 1.1-fold (0.07 log units) between middle value and limit.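

Going from phenyl to 4-methoxyphenyl gives an at least 1.1-fold higher number from compound 3 to compound 4 (0.07 log units; that floor lies within the scatter), the first single change shown on this aromatic ring, and it does not move the effect in this assay to smaller amounts of compound. On these data alone, compound 4 gives > 20000 nM, which is a limit of the assay and not a number, so the true size of the step stays unknown and its printed floor does not rise beyond the scatter. The same limit now recurs among these compounds: the limit of > 20000 nM in this assay, at which 2 of the 4 values shown sit.

As far as these compounds go, whether an amine or a carboxylic acid at this carbon would bring the number down into the measurable range remains open. From the compounds shown here alone, it is also open whether the same methoxy would behave alike on compound 2, which carries methyl in place of methoxy on the shared core.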